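From 6-methoxypyridin-3-yl to 1H-imidazol-4-yl on compound 2

The source may report more compounds than this note shows. Statements on the series, on what has been measured and on what is new or still open speak of the compounds shown alone.

Measured in a functional assay on SMMC-7721 cells (Homo sapiens) for inhibition, read by MTT assay, with a stated time of 48 h; a lower number here means a stronger inhibitor, a higher number a weaker inhibitor:
- compound 1 `COc1cc(NC(=O)Nc2ccccn2)cc(-c2cccnc2)c1OC`: 22400 nM
- compound 2 `COc1ccc(-c2cc(NC(=O)Nc3ccccn3)cc(OC)c2OC)cn1`: 32900 nM
- compound 3 `COc1ccc(-c2cc(NC(=O)Nc3ccncc3)cc(OC)c2OC)cn1`: "not determined" (no result reported)

Compound 2, at 32900 nM, lies within the usual scatter of compound 1, at 22400 nM, so the two cannot be ranked. Compound 3 adds no number for comparison.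

The next compound is compound 4 `COc1cc(NC(=O)Nc2ccccn2)cc(-c2c[nH]cn2)c1OC`, which differs from compound 2 in one place: 1H-imidazol-4-yl in place of 6-methoxypyridin-3-yl on an aromatic carbon. Among the measured compounds shown here, the swap sits on an aromatic carbon, ortho to a methoxy group, and brings in a five-membered aromatic ring that no measured compound carries.

For the measured compounds named here, only one measured step bears on it. That step, a 1.5-fold higher number from compound 1 to compound 2 (0.17 log units; within the scatter), alters the same group that compound 4 loses, and it stays within the scatter. It offers weak guidance for so large a swap, so no clear direction is expected in this assay, only wide uncertainty. The expected size of the change is a 1.1-fold lower number from compound 2 to compound 4 (0.04 log units; within the scatter).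

For compound 4 the estimated value is 30000 nM, with an expected range of 10000 nM to 85000 nM.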

Compound 4, half-maximal inhibitory concentration: 21200 nM
Beside the measured number, compound 4's estimate is 1.4-fold (0.15 log units) above it; the measured number falls inside the stated range.
By their numbers in this assay, from the lowest: compounds 4, 1 and 2 (each within the scatter of the next).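

In this assay this position accepts a five-membered aromatic ring without any change that can be told from scatter: there is a 1.6-fold lower number from compound 2 to compound 4 (0.19 log units; within the scatter) and a 1.1-fold lower number from compound 1 to compound 4 (0.02 log units; within the scatter) and neither step can be ranked. Thus 1H-imidazol-4-yl, with fewer heavy atoms than 6-methoxypyridin-3-yl and a hydrogen-bond donor that group lacks, leaves compounds 1, 2 and 4 on one level in this assay. Nothing measured here offers a reason for this result.

On these data alone, all three groups compared at this position are aromatic rings, so it remains open whether an amine, a carboxylic acid or a longer alkyl chain there would give a clear step. Compound 3 has no number, so the change that separates it from compound 2 also stays unread.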